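Swapping Fluorines for Bromine on a Triazole Aryl Group

This account rests on a few compounds, and the source may have more. Where it says the series, first, only, none or still open, it means among the compounds named here.

Going by the values given here, compound 2 `O=c1cc(Cn2cc(-c3cc(F)cc(F)c3)nn2)c2ccc(O)cc2o1` is the only compound in this set with a measured number in a functional assay on A549 cells (Homo sapiens) for inhibition, read by MTT assay, with a stated time of 72 h; a lower number here means a stronger inhibitor, a higher number a weaker inhibitor: compound 2 gives 21100 nM. Its relative compound 1 `O=c1cc(Cn2cc(CCCCO)nn2)c2ccc(O)cc2o1`, which carries a 4-hydroxybutyl chain where compound 2 carries a 3,5-difluorophenyl ring, reached only a limit: in this assay compound 1 gives > 100000 nM, which is a limit of the measurement rather than a number. Because of the limit of > 100000 nM in this assay, at which 1 of the 2 values shown sits, the step between the two can be stated only as a bound: an at least 4.7-fold lower number from compound 1 to compound 2 (0.67 log units; beyond the scatter).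

Compound 3 `O=c1cc(Cn2cc(-c3ccc(Br)cc3)nn2)c2ccc(O)cc2o1` has not yet been measured. Its change from compound 2 is 4-bromophenyl in place of 3,5-difluorophenyl on an aromatic carbon. Among the compounds with values here, the one measured step concerns a flexible chain giving way to an aromatic ring, whereas here one aromatic ring gives way to another, so that step bears on the question only loosely. Within the data shown here, no measured step compares two aromatic rings with each other, so no shift beyond the usual scatter is expected. Compound 3 is therefore estimated at 20000 nM, with a range from 7000 nM to 60000 nM. The step of a 1.1-fold lower number from compound 2 to compound 3 (0.02 log units; within the scatter) is expected to stay within the scatter.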

Compound 3, half-maximal inhibitory concentration: 32300 nM
Estimate against measurement, compound 3: 1.6-fold (0.21 log units) below; measured number inside the range.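

Placing one aromatic ring in the stead of another on this carbon of the five-membered aromatic ring with 3 nitrogen gives, in this assay, a 1.5-fold higher number from compound 2 to compound 3 (0.18 log units; within the scatter), so the 3,5-difluorophenyl and 4-bromophenyl groups cannot be told apart here, even though they differ in both the kind and the number of halogen atoms they carry. Compared with the 4-hydroxybutyl chain, the 4-bromophenyl ring gives an at least 3.0-fold lower number from compound 1 to compound 3 (0.49 log units; beyond the scatter), so a second aromatic ring, and not only the 3,5-difluorophenyl ring, now stands beyond the scatter from compound 1. The size of this step remains a bound and not a measured gap because of the value at its starting end: the limit of > 100000 nM in this assay, at which 1 of the 3 values shown sits.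

Open, as far as these compounds go, is how a phenyl ring with no halogen, or one carrying an amine or a carboxylic acid, would read in this assay beside compound 2 and compound 3. Also open, from the compounds shown here alone, is whether the ring itself or the hydroxyl end of the chain sets compound 1 apart, a question that a plain butyl chain or a benzyl group at this carbon would help to separate.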